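The source may hold more compounds than are shown below. What is called first, only, known or untested is meant among the compounds shown, and "the series" means these compounds.

Of the compounds shown here, three sharing one core have been tested in a functional assay on L02 cells (Homo sapiens) for inhibition, read by Griess assay, with stated times of 1 h and 24 h; on this read-out higher numbers stand for weaker inhibition and lower numbers for stronger inhibition. Compound 1 (`CCCCNc1nc(/C=C/c2ccccc2)nc2ccsc12`) gives > 1000000 nM, which is a limit of the assay and not a number. Compound 2 (`Brc1cccc(Nc2nc(/C=C/c3ccccc3)nc3ccsc23)c1`) gives > 1000000 nM, again a limit. Compound 3 (`Clc1ccccc1CNc1nc(/C=C/c2ccccc2)nc2ccsc12`) gives > 1000000 nM, also a limit. Compound 3 therefore stands with the other two, and the whole record so far is the limit of > 1000000 nM in this assay, at which 3 of the 3 values shown sit.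

Compound 4 (`COc1cccc(CNc2nc(/C=C/c3ccccc3)nc3ccsc23)c1`) has 3-methoxyphenyl in place of 2-chlorophenyl on a saturated chain carbon bound to a nitrogen on an aromatic ring.

Among the compounds with values here, three measured steps bear on this change: a step that the two limits leave unreadable from compound 1 to compound 3, a step that the two limits leave unreadable from compound 2 to compound 3 and a step that the two limits leave unreadable from compound 1 to compound 2. None of them has a readable size, so they give no measured guide to how much a change at this place can move this assay. Butyl, 3-bromophenyl and 2-chlorobenzyl on that nitrogen all ended at the same limit, so the likeliest outcome is that compound 4 ends there too, although a measurable number cannot be ruled out.

The expected result is a number no higher from compound 3 to compound 4 (the limit leaves the size open), with no firm direction expected. For compound 4 the estimated value is 1000000 nM, with an expected range from 150000 nM to 2000000 nM.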

Compound 4, half-maximal inhibitory concentration: > 1000000 nM
Compound 4 ended at the assay's limit; the forecaster's own chance of this, stated with the estimate: 75%; the middle value lies on the limit itself.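

Compound 4 ends at a limit and not at a number, as do compound 1, compound 2 and compound 3, so no step among these four compounds can be read: the limit of > 1000000 nM in this assay, at which 4 of the 4 values shown sit.

The compounds shown leave open whether any group on this nitrogen of the shared core can give a measurable inhibition value.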